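This account rests on a few compounds, and the source may have more. Where it says the series, first, only, none or still open, it means among the compounds named here.

In a functional assay on A549 cells (Homo sapiens) for cytotoxicity, read by CCK-8 assay, with a stated time of 24 h (a lower number here means a stronger inhibitor, a higher number a weaker inhibitor), compound 2 `C/C(=C\c1cc(-c2ccc(C)cc2)cs1)C(N)=O` gives > 50000 nM, which is a limit of the assay rather than a measured number. Compound 1 `C/C(=C\c1cc(-c2ccc(F)nc2)co1)C(N)=O` gives > 50000 nM, also a limit. Compound 3 `C/C(=C\c1nc(-c2ccc(C)cc2)cs1)C(N)=O` gives > 50000 nM, again a limit. Within the data shown here, the three values shown therefore share (the limit of > 50000 nM in this assay, at which 3 of the 3 values shown sit), and no step between measured compounds can be sized. Compound 4 `C=Cc1ccc(-c2csc(/C=C(\C)C(N)=O)c2)cc1` differs from compound 2 by vinyl in place of methyl on an aromatic carbon. For compound 4 the expected step is a step that the limit leaves unreadable from compound 2 to compound 4, meaning no change beyond the usual scatter, since every measured compound sits at the same limit. Compound 4 is expected to come in at about 60000 nM, with a range from 20000 nM to 200000 nM, and most likely to be reported once more as a limit.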

Compound 4, half-maximal inhibitory concentration: > 50000 nM
Compound 4: no number, only a limit (the forecaster's own chance of this, stated with the estimate: 75%); the middle value does not contradict the limit.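

No size can be read for the step between compound 2 and compound 4, since neither gives a number: the limit of > 50000 nM in this assay, at which 4 of the 4 values shown sit. The compounds shown leave open which change to the shared core, if any, would yield a measurable value.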